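This account rests on a few compounds, and the source may have more. Where it says the series, first, only, none or still open, it means among the compounds named here.

Measured so far:
compound 1 `CCOC(=O)c1cnn(-c2nc(-c3cccs3)c(C#N)c(=O)n2C)c1N` in a functional assay, with a stated time of 20 min (a lower number here means a stronger inhibitor, a higher number a weaker inhibitor), gives 79 ug/mL
compound 2 `CCOC(=O)c1cnn(-c2nc(-c3cccc(O)c3O)c(C#N)c(=O)n2C)c1N` in this assay gives 41 ug/mL

Among the compounds with values here, compound 2 has the lowest of the two numbers, but its only neighbour is compound 1, and the step of a 1.9-fold lower number from compound 1 to compound 2 (0.28 log units; within the scatter) lies within the scatter, so the two compounds cannot be told apart on these data. Compound 3 `CCOC(=O)c1cnn(-c2nc(-c3ccc(Cl)cc3)c(C#N)c(=O)n2C)c1N` differs from compound 2 in one place: 4-chlorophenyl in place of 2,3-dihydroxyphenyl on an aromatic carbon. Within the data shown here, no measured step replaces one phenyl group by another on this carbon, so no close comparison is available. Among the measured compounds shown here, the one step that exists, a 1.9-fold lower number from compound 1 to compound 2 (0.28 log units; within the scatter), exchanged a thiophen-2-yl for the 2,3-dihydroxyphenyl and did not move the number beyond the scatter. That is thin ground for predicting a 4-chlorophenyl, and the expectation is therefore for no step beyond the scatter in this assay, the estimated step being a 1.3-fold higher number from compound 2 to compound 3 (0.13 log units; within the scatter). Compound 3 is expected to give about 55 ug/mL, with a range from 25 ug/mL to 120 ug/mL.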

Compound 3, half-maximal inhibitory concentration: 64 ug/mL
Beside the measured number, compound 3's estimate is 1.2-fold (0.07 log units) below it, and the stated range covers the measured number.
By their numbers in this assay, from the lowest: compounds 2, 3 and 1 (each within the scatter of the next).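

In this assay, 4-chlorophenyl in place of 2,3-dihydroxyphenyl gives a 1.6-fold higher number from compound 2 to compound 3 (0.19 log units; within the scatter), and 4-chlorophenyl in place of thiophen-2-yl gives a 1.2-fold lower number from compound 1 to compound 3 (0.09 log units; within the scatter), so none of the three groups on this aromatic carbon can be told apart from the others. The new step also removes the hydrogen-bond donors and acceptors counted on the 2,3-dihydroxyphenyl, since the 4-chlorophenyl has neither, and the number still stays within the scatter; among these three compounds, then, those donors and acceptors are not required for a reading in this range. No separate data bear on why the three compounds read alike.

Going by these compounds, all three groups at this position are aromatic rings joined directly to the core, so it remains open whether an amine, a carboxylic acid or a longer alkyl chain on this carbon would move the number beyond the scatter. The rest of the core is the same in all three compounds, which also leaves open what a change elsewhere would do, such as a carboxylic acid in place of the ethyl ester.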